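The compounds below may be only part of what the source reports. "The series", "measured", "known", "first", "only" and "open" are said of these compounds alone.

Compounds measured so far:
- compound 1, `CCCC/C(=C(/c1ccc(/C=C/C(=O)O)cc1)c1ccc2[nH]ncc2c1)c1ccccc1`: 10 nM
- compound 2, `O=C(O)/C=C/c1ccc(/C(=C(/CCCl)c2ccccc2)c2ccc3[nH]ncc3c2)cc1`: 9 nM
- compound 3, `CC/C(=C(/c1ccc(/C=C/C(=O)O)cc1)c1ccc2[nH]nc(C)c2c1)c1ccccc1`: > 1000 nM

In a functional assay on MCF7 cells (Homo sapiens) for cytotoxicity, read by CellTiter-Glo, with a stated time of 5 days (on this read-out higher numbers stand for weaker inhibition and lower numbers for stronger inhibition), compound 3 gives only a limit, > 1000 nM, not a number, so it stands apart from the other two. Compound 4, `CC/C(=C(/c1ccc(/C=C/C(=O)O)cc1)c1cc(Cl)c2[nH]ncc2c1)c1ccccc1`, differs from compound 3 in one place: 7-chloro-1H-indazol-5-yl in place of 3-methyl-1H-indazol-5-yl on a double-bonded chain carbon bound to an aromatic carbon and a double-bonded chain carbon. For the measured compounds named here, the only measured step, a 1.1-fold lower number from compound 1 to compound 2 (0.05 log units; within the scatter), concerns a chain carbon and not this ring, so no measured step bears directly on the change. Compounds 1 and 2 lack the 3-methyl-1H-indazol-5-yl group and both sit at low numbers in this assay, whereas compound 3 sits at the limit of > 1000 nM in this assay, at which 1 of the 3 values shown sits. Removing that group is therefore expected to lower the number markedly, by about an at least 33-fold lower number from compound 3 to compound 4 (1.52 log units; beyond the scatter), and compound 4 is estimated at 30 nM, between 5 nM and 300 nM.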

Compound 4, half-maximal inhibitory concentration: 56 nM
For compound 4 the middle estimate is 1.9-fold (0.27 log units) below the measured one, within the range that was stated.
By their numbers in this assay, from the lowest: compounds 2 and 1 (each within the scatter of the next); then compound 4. At a limit, above all of these: compound 3.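

In this assay putting 7-chloro-1H-indazol-5-yl in place of 3-methyl-1H-indazol-5-yl gives a large step (an at least 17-fold lower number from compound 3 to compound 4 (1.25 log units; beyond the scatter)), so a change in this group can move the number well beyond the scatter. For the compounds shown here, the one earlier step, on the chain (a 1.1-fold lower number from compound 1 to compound 2 (0.05 log units; within the scatter)), showed no such shift. From the compounds shown here alone, compound 3 stands at a limit rather than a number, so the full size of the step stays unknown: the limit of > 1000 nM in this assay, at which 1 of the 4 values shown sits.

Going by these compounds, the methyl leaves and the chloro enters in the same step, so their separate shares remain open. On these data alone, whether a fluoro or a methoxy group in place of the chloro would give a similar number also remains open.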